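This account rests on a few compounds, and the source may have more. Where it says the series, first, only, none or still open, it means among the compounds named here.

Measured so far in an assay on HepG2 cells for displacement of a labelled ligand from Alpha-2C adrenergic receptor (Homo sapiens), tested at 0.1 uM; a higher number here means more inhibition at the concentration tested (going by the name of the read-out), a lower number less inhibition: compound 1 `CCCNC(=O)c1cccc(-c2cc3c(CN4CCc5cc(OC)c(OC)cc5C4)ccc(OC)c3o2)c1` gives 48%, and compound 2 `COc1cc2c(cc1OC)CN(Cc1ccc(OC)c3oc(-c4cccc(C(=O)NCCO)c4)cc13)CC2` gives 54%.

Compound 2 holds the higher of the two numbers, but the step of a number 6 percentage points higher from compound 1 to compound 2 (within the scatter) lies within the scatter, so the two cannot be told apart. Compound 3 `CCCNC(=O)c1cc2c(CN3CCc4cc(OC)c(OC)cc4C3)ccc(OC)c2o1` arises from compound 2 by propylcarbamoyl in place of 3-((2-hydroxyethyl)carbamoyl)phenyl on an aromatic carbon. For the measured compounds named here, the single measured step, a number 6 percentage points higher from compound 1 to compound 2 (within the scatter), concerns only the chain on the amide and says nothing about removing a whole phenyl ring, so no measured step bears on this change. With no guide, a drop is expected, with wide uncertainty: a number 24 percentage points lower from compound 2 to compound 3 (beyond the scatter). Compound 3 is estimated at 30%, within 5% to 60%.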

Compound 3, a percentage reported as inhibition, at one concentration (the size of the read-out at that concentration, not a potency): 20%
Compound 3: middle estimate off by 10 percentage points, on the high side; the range from low to high includes it.
By their numbers in this assay, from the lowest: compound 3; then compounds 1 and 2 (each within the scatter of the next).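

In this assay, the aromatic carbon next to the ring oxygen proves sensitive to losing the whole substituted phenyl ring: replacing it with propylcarbamoyl gives a number 34 percentage points lower from compound 2 to compound 3 (beyond the scatter) and also a number 28 percentage points lower from compound 1 to compound 3 (beyond the scatter) as the second view of the same change. The earlier pair varied only the end of the amide chain, whereas these steps show that the phenyl ring itself counts here. Nothing available explains the fall. Still open, from the compounds shown here alone, is whether the ring alone suffices: a plain phenyl without the amide, or a carboxylic acid in place of the amide on that ring, would separate the two.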